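The source may hold more compounds than are shown below. What is called first, only, known or untested is meant among the compounds shown, and "the series" means these compounds.

Two members of the series have numbers in a functional assay on COLO 205 cells (Homo sapiens) for inhibition, read by sulforhodamine B assay, with a stated time of 48 h, tested at 50 uM; on this read-out lower numbers stand for less inhibition of growth and higher numbers for more inhibition of growth at the one concentration tested. Compound 1 `COc1ccccc1/C=C/C(=O)/C=C/c1ccc(OCc2cn(CCOc3cc(=O)oc4ccccc34)nn2)c(OC)c1` gives 67% in this assay. Compound 2 `COc1cc(/C=C/C(=O)/C=C/c2cc(OC)c(OC)c(OC)c2)ccc1OCc1cn(CCCCCOc2cc(=O)oc3ccccc23)nn1` gives 51% in this assay, the lower of the two numbers; the gap to compound 1 lies beyond the scatter. Going by the values given here, the two differ in several places at once, so no single counted step connects them.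

Compound 3 `COc1cc(/C=C/C(=O)/C=C/c2ccco2)ccc1OCc1cn(CCCCCOc2cc(=O)oc3ccccc23)nn1` is the next one to go into this assay. Relative to compound 2 the change is furan-2-yl in place of 3,4,5-trimethoxyphenyl on a double-bonded chain carbon bound to a double-bonded chain carbon. Among the compounds with values here, no measured pair isolates this change, so the expectation rests only on where compound 2 stands. A small downward step is expected, one that may well stay within the scatter, and the expected step is a number 6 percentage points lower from compound 2 to compound 3 (within the scatter). For compound 3 the estimate in this assay is 45%, with a range from 25% to 65%.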

Compound 3, percent growth inhibition at one concentration: 33%
Beside the measured number, compound 3's estimate is 12 percentage points above it; measured number inside the range.
By their numbers in this assay, from the lowest: compound 3; then compound 2; then compound 1.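

In this assay, going by these compounds alone, furan-2-yl in place of 3,4,5-trimethoxyphenyl on a double-bonded chain carbon bound to a double-bonded chain carbon gives a number 18 percentage points lower from compound 2 to compound 3 (beyond the scatter) and so provides the first reading of a single-place change, showing that the group at this position affects growth inhibition. The change alters ring size, heavy-atom count and hydrogen-bond acceptor count together, and this one pair cannot separate them. Nothing at hand bears on why the number falls.

Still open, on these data alone, is whether a plain phenyl or a thiophene ring at this position would fall nearer compound 2 or compound 3. Within the data shown here, also open is whether the same exchange gives a similar step when a shorter chain replaces the one shared by compound 2 and compound 3.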